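Swapping a chloro for a hydroxy on the imine aryl

The source may report more compounds than this note shows. Statements on the series, on what has been measured and on what is new or still open speak of the compounds shown alone.

Measured compounds:
- Compound 1, `CCOc1cccc(/C=N/c2c(C)n(C)n(-c3ccccc3)c2=O)c1` — 295000000 nM
- Compound 2, `Cc1c(/N=C/c2ccccc2Cl)c(=O)n(-c2ccccc2)n1C` — 309000000 nM
- Compound 3, `COc1cccc(/C=N/c2c(C)n(C)n(-c3ccccc3)c2=O)c1O` — 240000000 nM

These three compounds share a core and differ only in the aromatic ring hanging from the carbon that carries a double bond to nitrogen. All were tested in a functional assay on HT-29 cells (Homo sapiens) for cytotoxicity, read by MTT assay, with a stated time of 72 h; a lower number here means a stronger inhibitor, a higher number a weaker inhibitor. In this assay compound 1 gives 295000000 nM, compound 2 gives 309000000 nM and compound 3 gives 240000000 nM. Compound 2 stands within the usual scatter of both companions: the gap to compound 1 and the gap to compound 3 are each too small to count as a real difference, so the three numbers cannot be told apart, and all of them sit at a level where cells are barely affected.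

Compound 4, `Cc1c(/N=C/c2ccc(O)cc2)c(=O)n(-c2ccccc2)n1C`, has not been tested yet. It differs from compound 2 in one place: 4-hydroxyphenyl in place of 2-chlorophenyl on a carbon with a double bond to nitrogen. Among the measured compounds shown here, no measured pair shows what such a change does here, so the expectation rests only on the fact that three different aryl groups gave indistinguishable numbers.

Compound 4 is therefore expected to land near its neighbours, at roughly 280000000 nM with a range from 100000000 nM to 800000000 nM. The expected step is a 1.1-fold lower number from compound 2 to compound 4 (0.04 log units; within the scatter), which means no change beyond the scatter.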

Compound 4, half-maximal inhibitory concentration: 389000000 nM
Compound 4: middle estimate off by 1.4-fold (0.14 log units), on the low side; measured number inside the range.
By their numbers in this assay, from the lowest: compounds 3, 1, 2 and 4 (each within the scatter of the next).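

In this assay, putting 4-hydroxyphenyl in place of 2-chlorophenyl on a carbon with a double bond to nitrogen gives a 1.3-fold higher number from compound 2 to compound 4 (0.10 log units; within the scatter) and so stays within the usual scatter of repeated measurements. Among the compounds shown here, this is the first one-place change that can be read directly, and it turns an impression from three separate aryl groups into a measured comparison. Even with chlorine leaving and oxygen entering, and with a hydrogen-bond donor and acceptor counted on the entering group but not on the leaving one, the number shows no real difference, although a single step cannot say how other groups would behave here. Nothing measured in this set explains this result.

Still open is whether any group at this position can bring the number well away from the level of these compounds, such as the one seen for compound 3 at 240000000 nM in this cell test. An amine or a carboxylic acid on the aromatic ring, or a longer chain in place of the ring, would test this, and the compounds shown do not say whether such changes would have any effect.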